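Methyl on the piperidine ring of compound 2

The compounds below may be only part of what the source reports. "The series", "measured", "known", "first", "only" and "open" are said of these compounds alone.

Compound 2 `COc1cc2c(Oc3ccc(NC(=O)c4cn(-c5c(C)cccc5C)nn4)cc3F)ccnc2cc1OCCCN1CCCCC1` gives 3520 nM in a functional assay on NCI-H460 cells (Homo sapiens) for cytotoxicity, read by MTT assay, with a stated time of 72 h (a lower number here means a stronger inhibitor, a higher number a weaker inhibitor), the highest number of the three measured. Compound 1 `COc1cc2c(Oc3ccc(NC(=O)c4cn(-c5ccccc5F)nn4)cc3F)ccnc2cc1OCCCN1CCCCC1` gives 210 nM and compound 3 `COc1cc2c(Oc3ccc(NC(=O)c4cn(-c5c(Cl)cccc5Cl)nn4)cc3F)ccnc2cc1OCCCN1CCCCC1` gives 280 nM; the steps of a 17-fold higher number from compound 1 to compound 2 (1.22 log units; beyond the scatter) and a 13-fold lower number from compound 2 to compound 3 (1.10 log units; beyond the scatter) both alter only the aryl on the aromatic nitrogen, while a 1.3-fold higher number from compound 1 to compound 3 (0.12 log units; within the scatter) stays within the scatter. Compound 4 `COc1cc2c(Oc3ccc(NC(=O)c4cn(-c5c(C)cccc5C)nn4)cc3F)ccnc2cc1OCCCN1CCC(C)CC1` differs from compound 2 by methyl in place of hydrogen on a saturated ring carbon. Among the compounds with values here, none of the measured steps touches the piperidin-1-yl end of the shared core; all three vary the aryl group. Lacking any comparable step, no change beyond the scatter is expected, and compound 4 is estimated at 3500 nM (range 1400 nM to 9000 nM). The expected step of a 1.0-fold lower number from compound 2 to compound 4 (0.00 log units; within the scatter) is therefore essentially none.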

Compound 4, half-maximal inhibitory concentration: 2360 nM
Beside the measured number, compound 4's estimate is 1.5-fold (0.17 log units) above it, within the range that was stated.
By their numbers in this assay, from the lowest: compounds 1 and 3 (each within the scatter of the next); then compounds 4 and 2 (each within the scatter of the next).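

In this assay, within the data shown here, 4-methylpiperidin-1-yl in place of piperidin-1-yl gives a 1.5-fold lower number from compound 2 to compound 4 (0.17 log units; within the scatter), the first reading at this end of the series. On the 2,6-dimethylphenyl compounds, a methyl on this saturated ring carbon, three ring bonds from the ring nitrogen, therefore leaves the number within the scatter, unlike the large aryl steps. Nothing at hand offers an explanation for this result.

Going by these compounds, whether the same step holds with 2-fluorophenyl or 2,6-dichlorophenyl on the aromatic nitrogen remains open. So does the outcome with a hydroxyl or carboxylic acid on that ring carbon, or with morpholine replacing piperidine.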